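The source may report more compounds than this note shows. Statements on the series, on what has been measured and on what is new or still open speak of the compounds shown alone.

Working notes on the series. The shared core is seen in compound 1 `C[C@@H]1CCCN1c1c(C#N)c2c(N)nc(Nc3cn[nH]c3)nc2n1C` and compound 2 `C[C@@H]1CCCN1c1c(C#N)c2c(N)ncnc2n1C`; compound 3 `C[C@@H]1CCCN1c1cc2c(N)ncnc2n1C` is the unmeasured member. In an assay on isolated protein for inhibition of Leucine-rich repeat serine/threonine-protein kinase 2 (Homo sapiens), read by TR-FRET and LanthaScreen, with stated times of 50 min and 30 min, in the presence of a further agent that is not named here (on this read-out higher numbers stand for weaker inhibition and lower numbers for stronger inhibition), compound 1 gives 6 nM, and in this assay compound 2 gives 15 nM. For the measured compounds named here, the one measured step, a 2.5-fold higher number from compound 1 to compound 2 (0.40 log units; beyond the scatter), is the loss of the (1H-pyrazol-4-yl)amino group, so compound 2 stands with the highest of the two numbers, the nearest being compound 1.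

The step from compound 2 to compound 3 is a different change: hydrogen in place of cyano on an aromatic carbon. Going by the values given here, none of the measured steps concerns the cyano group, so the step of a 2.5-fold higher number from compound 1 to compound 2 (0.40 log units; beyond the scatter) gives no guide to its size or direction; it only shows that removing a substituent from this core has so far moved the number upward beyond the scatter. The expectation for compound 3 is therefore a weaker inhibition than compound 2, with wide uncertainty, the step being estimated as a 4.0-fold higher number from compound 2 to compound 3 (0.60 log units; beyond the scatter). Compound 3 is expected to give about 60 nM in this assay, within a range of 15 nM to 300 nM.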

Compound 3, half-maximal inhibitory concentration: 6830 nM
The estimate for compound 3 lay 110-fold (2.06 log units) below the measured number; the measured number lies above the stated range.
By their numbers in this assay, from the lowest: compound 1; then compound 2; then compound 3.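

On the aromatic carbon next to the ring atom that bears a 2-methylpyrrolidin-1-yl group, hydrogen in place of cyano gives a 460-fold higher number from compound 2 to compound 3 (2.66 log units; beyond the scatter) in this assay on the shared core, so this single position carries a large part of the inhibition seen across these compounds. Set against a 2.5-fold higher number from compound 1 to compound 2 (0.40 log units; beyond the scatter) for the loss of the (1H-pyrazol-4-yl)amino group, a modest step, the change from cyano to hydrogen is the large one, and the two substituents do not weigh equally on this read-out. No measurement at hand bears on what lies behind the size of this step.

The two steps sit on different backgrounds, so the compounds shown leave open whether the (1H-pyrazol-4-yl)amino group would move the number by a similar amount on a core carrying hydrogen in place of cyano. They also leave open whether the result is particular to cyano, or whether another group on the same aromatic carbon, such as a chlorine atom, a carboxamide or an ethynyl group, would keep the number close to that of compound 2.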